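This account rests on a few compounds, and the source may have more. Where it says the series, first, only, none or still open, it means among the compounds named here.

In a functional assay on NALM-6 cells (Homo sapiens) for cytotoxicity, with a stated time of 72 h (on this read-out higher numbers stand for an effect only at larger amounts of compound and lower numbers for an effect already at smaller amounts), compound 1 (`C=C[C@@](C)(/C=C/c1ccc(O)c(/C=C/C(=O)c2ccccc2)c1)CCC=C(C)C`) gives 4470 nM. Compound 2 (`C=C[C@@](C)(/C=C/c1ccc(O)c(/C=C/C(=O)OCc2ccccc2)c1)CCC=C(C)C`) has no number, only a limit of the assay: > 43400 nM. Compound 3 (`C=C[C@@](C)(/C=C/c1ccc(O)c(/C=C/c2ccc(Cl)c(Cl)c2)c1)CCC=C(C)C`) carries 3,4-dichlorophenyl in place of benzyloxycarbonyl on a double-bonded chain carbon bound to a double-bonded chain carbon. Among the measured compounds shown here, one measured step bears on this, and only indirectly: an at least 9.7-fold higher number from compound 1 to compound 2 (0.98 log units; beyond the scatter), which introduced the benzyloxy group that compound 3 lacks. A move to a lower number of roughly that size is therefore expected, though compound 3 has a different group from compound 1. The expected change is an at least 4.8-fold lower number from compound 2 to compound 3 (0.68 log units; beyond the scatter). For compound 3 the estimate is 9000 nM, with an expected range of 2500 nM to 40000 nM.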

Compound 3, half-maximal effective concentration: 7510 nM
Estimate against measurement, compound 3: 1.2-fold (0.08 log units) above; the range from low to high includes it.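

In this assay, 3,4-dichlorophenyl in place of benzyloxycarbonyl gives an at least 5.7-fold lower number from compound 2 to compound 3 (0.76 log units; beyond the scatter). Compound 2 has only a limit of the assay, so this step has no exact size: the limit of > 43400 nM in this assay, at which 1 of the 3 values shown sits. The other new step, a 1.7-fold higher number from compound 1 to compound 3 (0.23 log units; within the scatter), shows that 3,4-dichlorophenyl and benzoyl cannot be told apart here, so the carbonyl of compound 1 is not required for an effect of this size.

From the compounds shown here alone, it remains open how an unsubstituted phenyl, an amine or a carboxylic acid would fare at this place. The compounds shown also do not tell whether either chlorine of compound 3 contributes.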